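A few compounds are considered here, and "the series" means these few. Any claim that something is new, unique, unknown or untested is made for them only; others in the source may bear on it.

Compound 1 `CC(C)c1n[nH]c2c(NCc3ccc(-c4ccccn4)cc3)nc(NCCO)nc12`: 51 nM
Compound 2 `CC(C)c1n[nH]c2c(NCc3ccc(-c4ccccn4)cc3)nc(N[C@@H]3CCCC[C@H]3N)nc12`: 295 nM

In a functional assay on MCF7 cells (Homo sapiens) for cytotoxicity, read by fluorescence, with a stated time of 72 h (on this read-out higher numbers stand for weaker inhibition and lower numbers for stronger inhibition), compound 1 gives 51 nM, the lowest of the two numbers, and compound 2 gives 295 nM. Compound 3 `COc1ccc(CNc2nc(NCc3ccc(-c4ccccn4)cc3)c3[nH]nc(C(C)C)c3n2)cc1` has not been measured. It differs from compound 1 by 4-methoxyphenyl in place of hydroxymethyl on a saturated chain carbon bound to a nitrogen on an aromatic ring. Among the compounds with values here, one measured step bears on this: a 5.8-fold higher number from compound 1 to compound 2 (0.76 log units; beyond the scatter), which also exchanged the 2-hydroxyethyl at the nitrogen on an aromatic ring. That exchange raised the number, so a modest rise is expected here as well, a 3.1-fold higher number from compound 1 to compound 3 (0.50 log units; beyond the scatter). Compound 3 is estimated at 160 nM, in a range from 50 nM to 500 nM.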

Compound 3, half-maximal inhibitory concentration: 5300 nM
The estimate for compound 3 lay 33-fold (1.52 log units) below the measured number; measured number outside the range, above it.
By their numbers in this assay, from the lowest: compound 1; then compound 2; then compound 3.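

Putting 4-methoxybenzyl on the nitrogen on an aromatic ring gives a 100-fold higher number from compound 1 to compound 3 (2.02 log units; beyond the scatter) and an 18-fold higher number from compound 2 to compound 3 (1.25 log units; beyond the scatter) in this assay and shows that this place can cost much more than the earlier exchange suggested. Among these three compounds, the two saturated groups give the lower numbers, and the group carrying a six-membered aromatic ring gives the highest. Nothing measured here accounts for the size of this rise.

On these data alone, it remains open whether the loss follows the aromatic ring, the methoxy group or the absence of the hydroxyl. A plain benzyl or a 2-aminoethyl chain at this nitrogen would help separate these.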